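Octyl in place of 4-bromophenyl on compound 3

A few compounds are considered here, and "the series" means these few. Any claim that something is new, unique, unknown or untested is made for them only; others in the source may bear on it.

Compound 1 `CC(=O)c1ccc(-n2cc(COc3ccc(/C=C/C(=O)c4cc5c(cc4O)OC(C)(C)CC5)cc3)nn2)cc1` gives 66300 nM here
Compound 2 `Cc1ccc(-n2cc(COc3ccc(/C=C/C(=O)c4cc5c(cc4O)OC(C)(C)CC5)cc3)nn2)cc1Br` gives 125000 nM here
Compound 3 `CC1(C)CCc2c(ccc(C(=O)/C=C/c3ccc(OCc4cn(-c5ccc(Br)cc5)nn4)cc3)c2O)O1` gives 129000 nM here

In a functional assay on A549 cells (Homo sapiens) for antiproliferative activity, read by MTT assay (a lower number here means a stronger inhibitor, a higher number a weaker inhibitor), compound 3 gives 129000 nM and stands within the scatter of both compound 1 and compound 2. None of the three separates from the others on these numbers.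

Compound 4 `CCCCCCCCn1cc(COc2ccc(/C=C/C(=O)c3ccc4c(c3O)CCC(C)(C)O4)cc2)nn1` has not yet been measured. It keeps the core of compound 3, whereas the cores of compound 1 and compound 2 differ from it. The structural change is octyl in place of 4-bromophenyl on an aromatic nitrogen and amounts to octyl in place of 4-bromophenyl on an aromatic nitrogen.

Within the data shown here, only one measured step bears on this site. It is a 1.9-fold higher number from compound 1 to compound 2 (0.28 log units; within the scatter) for 3-bromo-4-methylphenyl in place of 4-acetylphenyl on an aromatic nitrogen. That step exchanges one substituted phenyl for another, so the data hold no direct test of a chain replacing a phenyl. Resting on the small size of that one step, no change beyond the scatter is expected in this assay in either direction, and the uncertainty stays wide.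

The estimated step is a 1.4-fold lower number from compound 3 to compound 4 (0.16 log units; within the scatter) and is expected to stay within the scatter. For compound 4 the estimated value is 90000 nM with an expected range from 30000 nM to 200000 nM around it.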

Compound 4, half-maximal inhibitory concentration: "not active" (no number reported)
Compound 4: no number reported, so the estimate cannot be set against anything.
By their numbers in this assay, from the lowest: compounds 1, 2 and 3 (each within the scatter of the next).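

In this assay, among these compounds, compound 4 is recorded as not active, with no number reported, so no step from compound 3 to compound 4 can be read. The compounds shown leave open how octyl compares numerically with 4-bromophenyl on the aromatic nitrogen. Nothing available here accounts for this result.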